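A few compounds are considered here, and "the series" means these few. Any claim that something is new, unique, unknown or untested is made for them only; others in the source may bear on it.

Values in a functional assay on A549 cells (Homo sapiens) for antiproliferative activity, read by MTT assay, with a stated time of 48 h; on this read-out lower numbers stand for stronger inhibition and higher numbers for weaker inhibition:
- Compound 1 `CN1CCN(CCn2c(N)c(-c3nc4ccccc4[nH]3)c3nc(C#N)c(C#N)nc32)CC1`: 40500 nM
- Compound 2 `CCCCn1c(N)c(-c2nc3ccccc3[nH]2)c2nc(C#N)c(C#N)nc21`: > 50000 nM (a limit of the assay)

Compound 2 gives no number, only the limit > 50000 nM. This is the situation described by the limit of > 50000 nM in this assay, at which 1 of the 2 values shown sits.

Compound 3 `N#Cc1nc2c(-c3nc4ccccc4[nH]3)c(N)n(CCCN3CCCCC3)c2nc1C#N` differs from compound 2 by piperidin-1-yl in place of methyl on a saturated chain carbon, three bonds along the chain from an aromatic nitrogen. Cut one bond further out, butyl becomes 3-(piperidin-1-yl)propyl.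

For the measured compounds named here, the one measured step bearing on this is an at least 1.2-fold higher number from compound 1 to compound 2 (0.09 log units; that floor lies within the scatter), where ethyl replaces 4-methylpiperazin-1-yl. That step is small, and its floor stays within the scatter. Compound 3 will carry a saturated ring on its chain, as does compound 1, which gives 40500 nM and is the closest reference. A small move toward a lower number is therefore expected, with no strong gain.

The expected change is an at least 1.5-fold lower number from compound 2 to compound 3 (0.18 log units; that floor lies within the scatter). For compound 3 the estimated value is 33000 nM, with an expected range of 12000 nM to 60000 nM.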

Compound 3, half-maximal inhibitory concentration: 6110 nM
Compound 3: the middle estimate sits 5.4-fold (0.73 log units) above what was measured, and the stated range ends above it.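

In this assay, for the compounds shown here, a chain ending in a saturated ring gives the first step at this position that lies beyond the scatter, as butyl becomes 3-(piperidin-1-yl)propyl: an at least 8.1-fold lower number from compound 2 to compound 3 (0.91 log units; beyond the scatter). Compound 2 stands at a limit of the assay, which makes that step a floor only: the limit of > 50000 nM in this assay, at which 1 of the 3 values shown sits. A saturated ring on the chain is not enough on its own, as the step between the two ring-bearing compounds shows: a 6.6-fold lower number from compound 1 to compound 3 (0.82 log units; beyond the scatter).

That last step changes ring and chain length in one move, and the two stay unseparated until 2-(piperidin-1-yl)ethyl or 3-(4-methylpiperazin-1-yl)propyl is compared on the shared core. Open too, as far as these compounds go, is whether an open-chain amine such as dimethylamino, or a longer chain carrying piperidin-1-yl, holds the gain.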